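Trading propyl for methyl on a shorter chain

This account rests on a few compounds, and the source may have more. Where it says the series, first, only, none or still open, it means among the compounds named here.

In a functional assay on SH-SY5Y cells (Homo sapiens) for cytotoxicity, read by MTT assay, with a stated time of 72 h (on this read-out higher numbers stand for weaker inhibition and lower numbers for stronger inhibition), compound 3 (`CCCN1CCN(CCCCn2c3c(c4ccccc42)C(=O)c2c[n+]([O-])c4ccccc4c2C3=O)CC1`) gives 3970 nM, the highest of the three numbers measured. Compound 1 (`CN1CCN(CCCCn2c3c(c4ccccc42)C(=O)c2c[n+]([O-])c4ccccc4c2C3=O)CC1`) gives 100 nM and compound 2 (`O=C1c2c[n+]([O-])c3ccccc3c2C(=O)c2c1c1ccccc1n2CCCCN1CCNCC1`) gives 1240 nM.

Compound 4 (`CN1CCN(CCCn2c3c(c4ccccc42)C(=O)c2c[n+]([O-])c4ccccc4c2C3=O)CC1`) differs from compound 3 by 4-methylpiperazin-1-yl in place of (4-propylpiperazin-1-yl)methyl on a saturated chain carbon, three bonds along the chain from an aromatic nitrogen. That is 4-methylpiperazin-1-yl in place of (4-propylpiperazin-1-yl)methyl on a saturated chain carbon, three bonds along the chain from an aromatic nitrogen, so the end group and the chain both change.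

The closest evidence for the end group is the large 40-fold higher number from compound 1 to compound 3 (1.60 log units; beyond the scatter), which here runs in reverse, as propyl gives way to methyl. The large 12-fold higher number from compound 1 to compound 2 (1.09 log units; beyond the scatter) and the modest 3.2-fold higher number from compound 2 to compound 3 (0.51 log units; beyond the scatter) show that the group on this ring nitrogen matters in these compounds. Within the data shown here, no measured pair isolates the shorter chain, so its contribution is unknown.

A large step to a lower number is therefore expected, somewhat smaller than the reverse of the first step. The expected change is a 16-fold lower number from compound 3 to compound 4 (1.20 log units; beyond the scatter). Compound 4 is estimated at 250 nM, with an expected range of 50 nM to 1300 nM.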

Compound 4, half-maximal inhibitory concentration: 560 nM
Beside the measured number, compound 4's estimate is 2.2-fold (0.35 log units) below it, and the stated range covers the measured number.
By their numbers in this assay, from the lowest: compound 1; then compound 4; then compound 2; then compound 3.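

Among these compounds, compound 4 gives the first reading of the shorter chain on its own: with 4-methylpiperazin-1-yl kept as the end group, the shortening costs a 5.6-fold higher number from compound 1 to compound 4 (0.75 log units; beyond the scatter) in this assay, so the chain length at this position matters as well as the group on the ring nitrogen. The two steps that change the end group and the chain together, a 7.1-fold lower number from compound 3 to compound 4 (0.85 log units; beyond the scatter) and a 2.2-fold lower number from compound 2 to compound 4 (0.35 log units; beyond the scatter), both go to lower numbers, so the shortened methyl compound still ranks ahead of the longer propyl and unsubstituted compounds, though behind compound 1. Nothing measured here accounts for the effect of the shorter chain.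

The compounds shown leave open whether shortening the chain has the same effect with the 4-propylpiperazin-1-yl end group or the unsubstituted piperazine. They also leave open how a longer chain, or an ethyl group on the ring nitrogen, would behave.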